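Methoxy Added to Compound 2's Benzamide Ring

The source may report more compounds than this note shows. Statements on the series, on what has been measured and on what is new or still open speak of the compounds shown alone.

Measured compounds:
compound 1, `CCOC(=O)Cc1nc(N)n(C(=O)c2ccccc2)n1`: 38.5%
compound 2, `CCOC(=O)Cc1n[nH]c(NC(=O)c2ccccc2)n1`: 36.2%

In a functional assay on the whole organism (strain albino) for inhibition, with Rattus norvegicus as the target, read by paw edema, with stated times of 30 min and 2 h, at a dose of 5 mg/kg by the oral route (on this read-out lower numbers stand for less inhibition and higher numbers for more inhibition at the one dose given (going by the name of the read-out)), compound 2 gives 36.2%, the lower of the two numbers shown, while compound 1 gives 38.5%; the two lie within the scatter of each other, so neither stands apart. Compound 3, `CCOC(=O)Cc1n[nH]c(NC(=O)c2ccc(OC)cc2)n1`, carries one change from compound 2: methoxy in place of hydrogen on an aromatic carbon. For the measured compounds named here, no measured pair shows what such a change does in this assay, so the step from compound 2 to compound 3 is expected to stay within the scatter, in no set direction, a number 1.8 percentage points higher from compound 2 to compound 3 (within the scatter). Compound 3 is expected to give about 38%, between 25% and 52%.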

Compound 3, a percentage reported as inhibition, in the whole organism at one dose (the size of the read-out at that dose, not a potency): 38.2%
Compound 3: middle estimate off by 0.2 percentage points, on the low side, and the stated range covers the measured number.
By their numbers in this assay, from the lowest: compounds 2, 3 and 1 (each within the scatter of the next).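

For the compounds shown here, compound 2 and compound 3 give the first measured step for methoxy in place of hydrogen on an aromatic carbon, para to a large group: in this assay the change gives a number 2 percentage points higher from compound 2 to compound 3 (within the scatter), at the one dose given. The read-out therefore stays within the scatter when this group enters at this position. Nothing available explains this result. As far as these compounds go, whether an amine or a carboxylic acid at this same position would move the number beyond the scatter remains open.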